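A few compounds are considered here, and "the series" means these few. Any claim that something is new, unique, unknown or untested is made for them only; others in the source may bear on it.

Measured compounds in an assay on isolated protein for binding affinity to Alpha-1A adrenergic receptor (Homo sapiens), read by radioligand binding; a lower number here means a stronger inhibitor, a higher number a weaker inhibitor:
- compound 1 `COc1ccccc1N1CCN(CCNc2cc(-c3ccccc3)nn(C)c2=O)CC1`: 0.22 nM
- compound 2 `COc1ccc(Cl)cc1N1CCN(CCCNc2cc(-c3ccccc3)nn(C)c2=O)CC1`: 2 nM
- compound 3 `COc1ccccc1N1CCN(CCNc2c(C(=O)C(C)C)c(-c3ccccc3)nn(C)c2=O)CC1`: 0.18 nM

Compound 1 sits at the low end of the three numbers in this assay. Compound 3 gives a number that is within the scatter of it, the step being a 1.2-fold lower number from compound 1 to compound 3 (0.09 log units; within the scatter), so the two cannot be ordered. Within the data shown here, compound 2 differs from compound 1 in two places at once and gives a clearly higher number, the only value here that lies beyond the scatter of compound 1.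

Compound 4 `COc1ccccc1N1CCN(CCNc2cc(C)nn(C)c2=O)CC1` is not yet measured. The change from compound 1 is methyl in place of phenyl on an aromatic carbon. Among the measured compounds shown here, no measured step touches this position: the one step known, from compound 1 to compound 3, adds an isopropylcarbonyl elsewhere on the core and stays within the scatter, and compound 2 changes the linker and the aryl ring of the other end, not the phenyl. The phenyl is the largest group on the core and is cut to a single carbon, so a loss of affinity is expected rather than a neutral step, though its size is uncertain. Compound 4 is therefore expected to show a 14-fold higher number from compound 1 to compound 4 (1.13 log units; beyond the scatter) in this assay. The estimate for compound 4 is 3 nM, with a range from 0.5 nM to 20 nM.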

Compound 4, inhibition constant: 18.6 nM
Beside the measured number, compound 4's estimate is 6.2-fold (0.79 log units) below it; measured number inside the range.
By their numbers in this assay, from the lowest: compounds 3 and 1 (each within the scatter of the next); then compound 2; then compound 4.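

In this assay, among these compounds, the step of an 85-fold higher number from compound 1 to compound 4 (1.93 log units; beyond the scatter) is the first measured change at this aromatic carbon, and it shows that the group there strongly affects the number: phenyl and methyl are not interchangeable on the shared core. This contrasts with the step of a 1.2-fold lower number from compound 1 to compound 3 (0.09 log units; within the scatter), where adding isopropylcarbonyl at another aromatic carbon stays within the scatter, so the compounds shown tolerate that addition but not this replacement of phenyl with methyl. Nothing available bears on why the number rises when the six-carbon aromatic ring gives way to a single carbon.

With only phenyl and methyl shown at this carbon, it remains open whether the number follows the presence of an aromatic ring or simply the size of the group; cyclohexyl, a propyl chain, pyridyl or fluorophenyl there would help separate these readings. As far as these compounds go, it also remains open whether the same loss would appear with isopropylcarbonyl on the core, or with the longer linker and chlorine-bearing aryl ring of compound 2.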